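A few compounds are considered here, and "the series" means these few. Any claim that something is new, unique, unknown or untested is made for them only; others in the source may bear on it.

Within the data shown here, in a functional assay on HT-1080 cells (Homo sapiens) for antiproliferative activity, read by MTT assay, with a stated time of 72 h (a higher number here means a weaker inhibitor, a lower number a stronger inhibitor), compound 1 (`CCOC(=O)c1cc(-c2ccc(OC)cc2)c(-c2cc(OC)c(OC)c(OC)c2)s1`) gives 7630 nM and holds the lowest of the three numbers so far. Compound 2 (`CCOC(=O)c1cc(-c2ccc(OC)c([N+](=O)[O-])c2)c(-c2cc(OC)c(OC)c(OC)c2)s1`) gives 26100 nM and compound 3 (`CCOC(=O)c1cc(-c2ccc(OC)c(O)c2)c(-c2cc(OC)c(OC)c(OC)c2)s1`) gives 82600 nM in the same test. Compound 4 (`COc1ccc(-c2ccsc2-c2cc(OC)c(OC)c(OC)c2)cc1`) changes compound 1 elsewhere, with hydrogen in place of ethoxycarbonyl on an aromatic carbon. The nearest evidence is a 3.4-fold higher number from compound 1 to compound 2 (0.53 log units; beyond the scatter) (modest) and an 11-fold higher number from compound 1 to compound 3 (1.03 log units; beyond the scatter) (large) on the 4-methoxyphenyl group. Both added a group and raised the number, but neither touches the ethoxycarbonyl, so they guide only weakly. Compound 4 loses a group, so a modest drop is tentatively expected, with the estimated step being a 2.5-fold lower number from compound 1 to compound 4 (0.41 log units; beyond the scatter) in size. For compound 4 the estimated value is 3000 nM within a range of 300 nM to 30000 nM overall.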

Compound 4, half-maximal inhibitory concentration: 3620 nM
Estimate against measurement, compound 4: 1.2-fold (0.08 log units) below; low and high end bracket the measured number.
By their numbers in this assay, from the lowest: compound 4; then compound 1; then compound 2; then compound 3.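

In this assay, putting hydrogen in place of the ethoxycarbonyl next to the ring sulfur gives a 2.1-fold lower number from compound 1 to compound 4 (0.32 log units; beyond the scatter) and is the first change shown at this position. Among these compounds, the ethoxycarbonyl is therefore not required for the activity of compound 1 in this test, and the lowest number so far comes without it. Nothing measured here explains why the number falls. The compounds shown leave open how other groups would behave at this position, such as a carboxylic acid, an amide or a methyl group.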